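Hydroxymethyl for Methyl on a Cyclohexane Carboxamide Glycine Side Chain

A few compounds are considered here, and "the series" means these few. Any claim that something is new, unique, unknown or untested is made for them only; others in the source may bear on it.

The measured compounds:
compound 1 `O=C(O)CNC(=O)[C@]1(O)C[C@@H](O)[C@@H](O)[C@H](O)C1` gives 38%
compound 2 `O=C(O)CCCNC(=O)[C@]1(O)C[C@@H](O)[C@@H](O)[C@H](O)C1` gives 83%
compound 3 `C[C@H](NC(=O)[C@]1(O)C[C@@H](O)[C@@H](O)[C@H](O)C1)C(=O)O` gives 8%

In an assay on HL-60 cells for inhibition of P-selectin (Homo sapiens), tested at 50 mM (on this read-out lower numbers stand for less inhibition and higher numbers for more inhibition at the one concentration tested (going by the name of the read-out)), compound 3 stands lowest of the three. Its nearest neighbour is compound 1, and the step of a number 30 percentage points lower from compound 1 to compound 3 (beyond the scatter) shows what a methyl costs here; the step of a number 75 percentage points lower from compound 2 to compound 3 (beyond the scatter) is larger still. Compound 4 `O=C(O)[C@H](CO)NC(=O)[C@]1(O)C[C@@H](O)[C@@H](O)[C@H](O)C1` differs from compound 3 by hydroxy in place of hydrogen on a saturated chain carbon, two bonds along the chain from an amide-type nitrogen and a carbonyl carbon. For the measured compounds named here, no measured step replaces a hydrogen with a hydroxy, so the two steps only mark how much this side chain can move the read-out, not the direction of this change. A small upward step is expected, a number 12 percentage points higher from compound 3 to compound 4 (beyond the scatter), since compound 3 sits near the floor. Compound 4 is expected to give 20%, between 0% and 50%.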

Compound 4, a percentage reported as inhibition, at one concentration (the size of the read-out at that concentration, not a potency): 88%
Compound 4: middle estimate off by 68 percentage points, on the low side; measured number outside the range, above it.
By their numbers in this assay, from the lowest: compound 3; then compound 1; then compounds 2 and 4 (each within the scatter of the next).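

Methyl to hydroxymethyl on this saturated chain carbon gives a number 80 percentage points higher from compound 3 to compound 4 (beyond the scatter), so a single hydroxy decides whether this branched side chain sits at the bottom or the top of the series. Against the unbranched side chain of compound 1, hydroxymethyl in place of hydrogen gives a number 50 percentage points higher from compound 1 to compound 4 (beyond the scatter), the opposite direction to methyl, and the 1-carboxy-2-hydroxyethyl group stands level with 3-carboxypropyl, at a number 5 percentage points higher from compound 2 to compound 4 (within the scatter). Nothing available explains why this hydroxy has so large an effect. On these data alone, whether an aminomethyl or a methoxymethyl group on this carbon would match hydroxymethyl stays open, as does the effect of the opposite configuration there.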